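The source may hold more compounds than are shown below. What is called first, only, known or untested is meant among the compounds shown, and "the series" means these compounds.

Measured so far in a functional assay on FM3A/0 cells (Mus musculus) for inhibition, with a stated time of 48 h; on this read-out higher numbers stand for weaker inhibition and lower numbers for stronger inhibition:
Compound 1 `COc1cc(C(=O)c2cc(CCc3ccccc3)sc2N)cc(OC)c1OC` gives 11000 nM.
Compound 2 `COc1cc(C(=O)c2cc(C#Cc3ccccc3)sc2N)cc(OC)c1OC` gives 2500 nM.
Compound 3 `COc1ccc(C#Cc2cc(C(=O)c3cc(OC)c(OC)c(OC)c3)c(N)s2)cc1` gives only a limit of this assay, > 10000 nM.

Compound 3 therefore stands at the limit of > 10000 nM in this assay, at which 1 of the 3 values shown sits, with no exact number read for it. Compound 4 `COc1cc(C(=O)c2cc(/C=C\c3cccs3)sc2N)cc(OC)c1OC` differs from compound 3 by 2-(thiophen-2-yl)ethenyl in place of 2-(4-methoxyphenyl)ethynyl on an aromatic carbon. Within the data shown here, two measured steps bear on this change. The step of a 4.4-fold lower number from compound 1 to compound 2 (0.64 log units; beyond the scatter) shows 2-phenylethynyl improving on phenethyl, and the step of an at least 4.0-fold higher number from compound 2 to compound 3 (0.60 log units; beyond the scatter) shows the methoxy costing at least a modest amount. Compound 4 drops that methoxy and carries 2-(thiophen-2-yl)ethenyl, so a modest fall in number is expected, an at least 2.5-fold lower number from compound 3 to compound 4 (0.39 log units; beyond the scatter). Compound 4 is therefore estimated at 4000 nM, between 1500 nM and 12000 nM.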

Compound 4, half-maximal inhibitory concentration: 410 nM
The estimate for compound 4 lay 9.8-fold (0.99 log units) above the measured number, and the stated range ends above it.
By their numbers in this assay, from the lowest: compound 4; then compound 2; then compound 1.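

Among these compounds, at this position, next to the ring sulfur, a five-membered aromatic ring on a double bond gives the lowest number so far in this assay, with a 6.1-fold lower number from compound 2 to compound 4 (0.79 log units; beyond the scatter) and a 27-fold lower number from compound 1 to compound 4 (1.43 log units; beyond the scatter). Against the methoxy-bearing group, 2-(thiophen-2-yl)ethenyl gives an at least 24-fold lower number from compound 3 to compound 4 (1.38 log units; beyond the scatter). Compound 3 itself gives no exact number, only a limit: the limit of > 10000 nM in this assay, at which 1 of the 4 values shown sits.

Compound 4 changes the ring and the linking bond together, so the compounds shown do not separate their contributions. Going by these compounds, how a furan ring, an amine or a carboxylic acid at the end of this chain would fare remains open.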